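This account rests on a few compounds, and the source may have more. Where it says the series, first, only, none or still open, it means among the compounds named here.

Working notes on the ester series. The shared core carries in compound 1 `CC(C)(C)OC(=O)OCOC(=O)C(C)(C)Oc1ccc(C(=O)c2ccc(Cl)cc2)cc1` a ((tert-butoxycarbonyl)oxy)methyl ester; in a physicochemical assay for solubility, read by HPLC, in phosphate buffer, with a stated time of 4 h, at pH 7.4 (on this read-out lower numbers stand for lower solubility and higher numbers for higher solubility), compound 1 gives 0.002 ug/mL. Compound 2 `CC(=O)OC(C)OC(=O)C(C)(C)Oc1ccc(C(=O)c2ccc(Cl)cc2)cc1` carries a 1-acetoxyethyl ester and in this assay compound 2 gives 0.002 ug/mL. Compound 3 `CC(C)OC(=O)OCOC(=O)C(C)(C)Oc1ccc(C(=O)c2ccc(Cl)cc2)cc1` carries a ((isopropoxycarbonyl)oxy)methyl ester and in this assay compound 3 gives 0.002 ug/mL. Compound 1 stands level with compounds 2 and 3 at the digits shown. The three pairwise steps read: no change at the digits printed from compound 1 to compound 2 (within the scatter); no change at the digits printed from compound 1 to compound 3 (within the scatter); no change at the digits printed from compound 2 to compound 3 (within the scatter). Across the three measured ester groups, the read-out does not move.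

Compound 4 `Cc1oc(=O)oc1COC(=O)C(C)(C)Oc1ccc(C(=O)c2ccc(Cl)cc2)cc1` differs from compound 1 only at the ester: a group of 7 heavy atoms (4 carbon, 3 oxygen; one five-membered aromatic ring with 2 hetero atoms) in place of a group of 8 heavy atoms (5 carbon, 3 oxygen; no ring), on a saturated chain carbon bound to an oxygen next to a carbonyl group. The three measured steps all change the same ester group and all stay within the scatter, so they bear directly on this step, and none of them moved the read-out. With the core unchanged and the ester again swapped for a group of similar size, no step beyond the scatter is expected in either direction for compound 4, which is expected to sit at 0.002 ug/mL with a range of 0.001 ug/mL to 0.005 ug/mL. The step from compound 1 to compound 4 is therefore estimated as no change at the digits printed from compound 1 to compound 4 (within the scatter).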

Compound 4, solubility: 0.002 ug/mL
For compound 4 middle estimate and measured number coincide at the digits printed; the measured number falls inside the stated range.
By their numbers in this assay, from the lowest: compounds 1, 2, 3 and 4 (each within the scatter of the next).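

Set against the earlier compounds, the new ester adds one thing: in this assay the read-out also holds when a group with one five-membered aromatic ring with 2 hetero atoms enters at this place, on a saturated chain carbon bound to an oxygen next to a carbonyl group (no change at the digits printed from compound 1 to compound 4 (within the scatter)). The same holds against the other two ring-free esters (no change at the digits printed from compound 3 to compound 4 (within the scatter)) and (no change at the digits printed from compound 2 to compound 4 (within the scatter)), so the earlier picture, drawn only from exchanges between ring-free groups, now extends to one ring-bearing group, and within these four compounds the presence of that ring leaves no mark on the read-out. No measurement at hand offers an explanation for this flat result.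

The compounds shown leave open whether an ester group carrying an amine or a carboxylic acid would separate from compound 1 at 0.002 ug/mL in this assay. They also leave open whether a longer chain in the ester, or any change to the shared core itself, would move the read-out, since all four compounds keep that core unchanged.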